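This account rests on a few compounds, and the source may have more. Where it says the series, first, only, none or still open, it means among the compounds named here.

Measured so far:
compound 1 `COc1ccc(Nc2nc(N)c(C(=O)c3ccccc3)s2)cc1`: 230 nM
compound 2 `COc1ccc(Nc2nc(N)c(C(=O)c3ccc(OC)c(OC)c3)s2)cc1`: 52 nM
compound 3 `Nc1nc(Nc2ccc(Cl)cc2)sc1C(=O)c1ccccc1`: > 10000 nM, which is a limit of the assay and not a number

All three compounds were tested in a functional assay on HeLa cells (Homo sapiens) for antiproliferative activity, read by cell counting, with a stated time of 2 days; on this read-out lower numbers stand for stronger inhibition and higher numbers for weaker inhibition. There compound 1 gives 230 nM, the higher of the two true numbers, and compound 2 gives the lower one, 52 nM.

The unmeasured compound 4 `COc1ccc(Nc2nc(N)c(C(=O)c3ccc(Br)cc3)s2)cc1` keeps the core of compound 1 and turns its phenyl into 4-bromophenyl. This puts bromo in place of hydrogen on an aromatic carbon, para to a large group: bromo in place of hydrogen on an aromatic carbon.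

For the measured compounds named here, the only measured step that changes a single place is an at least 43-fold higher number from compound 1 to compound 3 (1.63 log units; beyond the scatter), with chloro in place of methoxy on an aromatic carbon. That step was large, but it lies elsewhere in the molecule than the new bromo, so it bears on compound 4 only loosely. Going by the values given here, no measured step covers bromo at this place, so no change beyond the scatter is expected in this assay, in either direction, and the uncertainty remains wide. The expectation therefore starts from compound 1 at 230 nM. The estimate amounts to a 1.2-fold lower number from compound 1 to compound 4 (0.06 log units; within the scatter). For compound 4 the expected value is 200 nM, with an estimated range from 50 nM to 1200 nM.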

Compound 4, half-maximal inhibitory concentration: 79 nM
Estimate against measurement, compound 4: 2.5-fold (0.40 log units) above, and the stated range covers the measured number.
By their numbers in this assay, from the lowest: compounds 2 and 4 (each within the scatter of the next); then compound 1. At a limit, above all of these: compound 3.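

Replacing hydrogen with bromo on an aromatic carbon of the phenyl ring, para to a large group, gives a 2.9-fold lower number from compound 1 to compound 4 (0.46 log units; beyond the scatter) in this assay. For the compounds shown here, this is a modest step, but it shows that this carbon can carry a bromine atom and that the change from phenyl to 4-bromophenyl improves the read-out, whereas the only earlier single-place step, an at least 43-fold higher number from compound 1 to compound 3 (1.63 log units; beyond the scatter), lies elsewhere in the molecule and runs the opposite way. The compounds shown give no measured property that explains this gain.

On these data alone, it remains open whether bromine itself matters or whether other groups on the same carbon, such as fluoro, chloro, methyl, an amine or a carboxylic acid, would give a similar or a different number in this assay. As far as these compounds go, it also remains open whether bromo on another carbon of this ring would have the same effect, and whether the gain would carry over to a compound with other changes to the shared core.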